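A few compounds are considered here, and "the series" means these few. Any claim that something is new, unique, unknown or untested is made for them only; others in the source may bear on it.

For the measured compounds named here, compound 3 `COc1cc(-c2nnc(SCC(=O)c3ccc(F)cc3)n2N2C(=O)c3ccccc3C2=O)cc(OC)c1OC` is the only one of the three compounds with a numerical result: in a functional assay on MKN-45 cells (Homo sapiens) for cytotoxicity, read by MTT assay, with a stated time of 48 h (on this read-out lower numbers stand for stronger inhibition and higher numbers for weaker inhibition), compound 3 gives 126000 nM. Compound 1 `COc1cc(-c2nnc(SC)n2N2C(=O)c3ccccc3C2=O)cc(OC)c1OC` reaches only a limit of this assay, > 200000 nM. Compound 2 `COc1cc(-c2nnc(SCC(=O)c3ccccc3)n2N2C(=O)c3ccccc3C2=O)cc(OC)c1OC` likewise gives only a limit, > 200000 nM. Compound 4 `COc1cc(-c2nnc(SCC(=O)c3ccc(Br)cc3)n2N2C(=O)c3ccccc3C2=O)cc(OC)c1OC` differs from compound 3 by bromo in place of fluoro on an aromatic carbon. Going by the values given here, the only measured step at that aromatic carbon, an at least 1.5-fold lower number from compound 2 to compound 3 (0.20 log units; that floor lies within the scatter), placed fluoro in place of hydrogen, and no step exchanging one halogen for another has been measured. The step to compound 4 is therefore expected to be small, a 1.3-fold lower number from compound 3 to compound 4 (0.10 log units; within the scatter), and not beyond the usual scatter. Compound 4 is estimated at 100000 nM, with a range from 40000 nM to 250000 nM.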

Compound 4, half-maximal inhibitory concentration: 22300 nM
The estimate for compound 4 lay 4.5-fold (0.65 log units) above the measured number; the whole stated range lies above it.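

On the aromatic carbon para to a large group, the choice of halogen clearly matters: in this assay, bromo in place of fluoro gives a 5.7-fold lower number from compound 3 to compound 4 (0.75 log units; beyond the scatter). Bromo in place of hydrogen gives an at least 8.9-fold lower number from compound 2 to compound 4 (0.95 log units; beyond the scatter), and the whole (4-bromophenyl)carbonyl group in place of hydrogen gives an at least 8.9-fold lower number from compound 1 to compound 4 (0.95 log units; beyond the scatter). Both of these sizes are only floors, because compound 1 and compound 2 stop at a limit of the assay: the limit of > 200000 nM in this assay, at which 2 of the 4 values shown sit.

Where chloro or iodo on this carbon would fall stays open. So does whether a non-halogen group such as methoxy or an amine could match bromo.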